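A few compounds are considered here, and "the series" means these few. Any claim that something is new, unique, unknown or untested is made for them only; others in the source may bear on it.

Measured compounds:
compound 1, `O=C(O)c1ccc(C(=O)/C(=C\c2ccc([N+](=O)[O-])c(O)c2)SCc2ccc(Br)cc2)cc1`, 10000 nM
compound 2, `O=C(O)c1cc(/C=C(/Sc2ccc(Br)cc2)C(=O)c2c(F)c(F)c(F)c(F)c2F)ccc1O`, 25000 nM
compound 3, `O=C(/C(=C\c1ccc([N+](=O)[O-])c(O)c1)SCc1ccc(Br)cc1)c1ccc(Br)cc1`, 10000 nM

All three values come from a functional assay on DU-145 cells (Homo sapiens) for inhibition, read by trypan blue exclusion, with a stated time of 96 h; a higher number here means a weaker inhibitor of growth, a lower number a stronger inhibitor of growth. In this assay compound 1 gives 10000 nM and compound 3 gives 10000 nM; the change between them, (bromo in place of carboxy on an aromatic carbon), gives no change at the digits printed from compound 1 to compound 3 (within the scatter). In this assay compound 2 gives 25000 nM, the highest number of the three, and its gaps to compound 1 and to compound 3 both lie beyond the scatter, so compound 2 is the weakest inhibitor of growth in this set. How the core of compound 2 differs from the core of compound 1 is not broken down here.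

Compound 4, `O=C(/C(=C\c1ccc(O)c(Br)c1)Sc1ccc(Br)cc1)c1c(F)c(F)c(F)c(F)c1F`, is not yet measured. It differs from compound 2 by bromo in place of carboxy on an aromatic carbon. This is the same kind of change as from compound 1 to compound 3, not the same one: in compound 1 the leaving carboxy sits para to a large group, whereas in compound 2 it sits ortho to a hydroxy group and meta to a large group, on a different core.

Within the data shown here, the only precedent is a step within the scatter, and the surroundings of the change differ, which widens the uncertainty. Set against no change at the digits printed from compound 1 to compound 3 (within the scatter), the estimate is expected to mean a 1.1-fold lower number from compound 2 to compound 4 (0.06 log units; within the scatter), resting on that single precedent. Compound 4 is estimated at 22000 nM in this assay, with a likely range from 8000 nM to 60000 nM.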

Compound 4, concentration for 50% growth inhibition: 1000 nM
Compound 4: middle estimate off by 22-fold (1.34 log units), on the high side, and the stated range ends above it.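

In this assay the exchange of carboxy for bromo gives a 25-fold lower number from compound 2 to compound 4 (1.40 log units; beyond the scatter), so the flat result of the same exchange on the core of compound 1 does not carry over to the core of compound 2. Among these compounds, the two readings of this one change do not agree: the same change on two cores in this assay, no change at the digits printed (within the scatter) from compound 1 to compound 3 and a 25-fold lower number (1.40 log units; beyond the scatter) from compound 2 to compound 4, 25-fold (1.40 log units) apart, beyond the scatter of two such steps The comparison shows that, across these two cores, the outcome of this exchange depends on the core that carries it, but it does not show which of the several differences between the cores is responsible, and with only one pair on each core it gives no rule for predicting the step on a third core.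

Still open, going by these compounds, is whether the large step from the 3-carboxy-4-hydroxyphenyl to the 3-bromo-4-hydroxyphenyl group is particular to bromo, or whether chloro, methyl or a nitrile at the same place on the core of compound 2 would give a similar number. Also open, on these data alone, is how much of the step depends on the neighbouring hydroxy group, which a methoxy group in its place on compound 4 would test, and whether the same exchange follows compound 2 or compound 1 on cores that mix their features.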